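This account rests on a few compounds, and the source may have more. Where it says the series, first, only, none or still open, it means among the compounds named here.

In a functional assay on HO8910 cells (Homo sapiens) for inhibition, read by MTT assay, with a stated time of 24 h, tested at 10 ug/mL (on this read-out higher numbers stand for more inhibition of growth at the one concentration tested and lower numbers for less inhibition of growth), compound 1 `O=C(O)CCCCC(CCSC(=O)c1ccccc1)SC(=O)c1ccccc1` gives "not active" (no number reported) and compound 2 `O=C(CCCCC(S)CCS)Nc1ccc(Cl)cc1` gives "not active" (no number reported). Among the compounds with values here, compound 3 `O=C(CCCCC(CCSC(=O)c1ccccc1)SC(=O)c1ccccc1)Nc1ccccc1Cl` gives 1.33%, the only number so far, so it cannot be ranked against a second number. Compound 4 `O=C(CCCCC(CCSC(=O)c1ccccc1)SC(=O)c1ccccc1)Nc1ccc(Cl)cc1` is still unmeasured and differs from compound 3 thus: 4-chlorophenyl in place of 2-chlorophenyl on an amide-type nitrogen. In words, this is 4-chlorophenyl in place of 2-chlorophenyl on an amide-type nitrogen, with the same atoms joined differently. Within the data shown here, no measured step covers this change, so no shift beyond the scatter is expected in this assay, and no direction is assumed. The estimated change is a number 1.7 percentage points higher from compound 3 to compound 4 (within the scatter). For compound 4 the expected value is 3%, with an estimated range of 0% to 14%.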

Compound 4, percent growth inhibition at one concentration: "not active" (no number reported)
The entry for compound 4 holds no number; the estimate stays without a comparison.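

In this assay, within the data shown here, compound 4 gives "not active" (no number reported) and leaves no step from compound 3 to read. As far as these compounds go, what 4-chlorophenyl in place of 2-chlorophenyl does to growth inhibition stays open, and no supporting evidence bears on this result.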